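Nitro for cyano on a second core: what to expect

A few compounds are considered here, and "the series" means these few. Any claim that something is new, unique, unknown or untested is made for them only; others in the source may bear on it.

The study compares two cores that carry the same pair of substituents on the aromatic ring. Compound 1 `N#Cc1ccc2c(c1)[C@@H](N1CCCC1=O)[C@H](O)C(CF)(CF)O2` has a cyano group; in a functional assay (aorta) with Rattus norvegicus as the target (a lower number here means that less compound is needed, a higher number that more compound is needed for the effect), compound 1 gives 85.1 nM. Compound 2 `O=C1CCCN1[C@@H]1c2cc([N+](=O)[O-])ccc2OC(CF)(CF)[C@H]1O` differs from it in one place, (nitro in place of cyano on an aromatic carbon), and in this assay compound 2 gives 24 nM. That single change made the step of a 3.5-fold lower number from compound 1 to compound 2 (0.55 log units; beyond the scatter).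

Compound 3 `N#Cc1ccc2c(c1)C(n1ccccc1=O)=CC(CF)(CF)O2` belongs to a different core; how its core differs from that of compound 1 is not broken down here. In this assay compound 3 gives 24.6 nM, a number that sits next to that of compound 2 and clearly apart from that of compound 1.

Compound 4 `O=c1ccccn1C1=CC(CF)(CF)Oc2ccc([N+](=O)[O-])cc21` has not yet been measured. It relates to compound 3 in exactly the way compound 2 relates to compound 1: nitro in place of cyano on an aromatic carbon. Among the compounds with values here, the change is the same one seen once before, on the same kind of aromatic carbon, and the only measured instance of it produced the step of a 3.5-fold lower number from compound 1 to compound 2 (0.55 log units; beyond the scatter). Since compound 3 starts from 24.6 nM, the same step would carry compound 4 well into the single digits. The expectation rests on one pair only, so it is held with some caution and the range is left wide. The step from compound 3 to compound 4 is expected to be a 3.1-fold lower number from compound 3 to compound 4 (0.49 log units; beyond the scatter). For compound 4 in this assay the estimate is 8 nM, most likely between 3 nM and 25 nM.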

Compound 4, half-maximal effective concentration: 2.46 nM
For compound 4 the middle estimate is 3.3-fold (0.51 log units) above the measured one; the measured number lies below the stated range.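

Measured in this assay, the replacement of cyano by nitro on the second core gives a 10-fold lower number from compound 3 to compound 4 (1.00 log units; beyond the scatter), so the number falls in the same direction as on the first core, but by a different amount. Set side by side, the two steps do not match: the same change on two cores in this assay, a 3.5-fold lower number (0.55 log units; beyond the scatter) from compound 1 to compound 2 and a 10-fold lower number (1.00 log units; beyond the scatter) from compound 3 to compound 4, 2.8-fold (0.45 log units) apart, beyond the scatter of two such steps. The direction of the change therefore held on both cores shown, but the size of the step did not carry over from one core to the other, and two pairs cannot show which feature of the cores sets the sizes apart or how large the step would be on a third core.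

The compounds shown carry only cyano or nitro on this aromatic carbon, so it remains open whether another group there, such as an amine, a carboxylic acid or a chlorine atom, would lower the number on both cores or give steps that differ between them in the same way. From the compounds shown here alone, it also remains open whether the gap between the two steps is specific to the replacement of cyano by nitro or would appear with other replacements on these two cores.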